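Solubility working notes: from compound 2 toward compound 4

This account rests on a few compounds, and the source may have more. Where it says the series, first, only, none or still open, it means among the compounds named here.

Measured so far:
Compound 1 `Cc1cc(C)cc(NC(=O)COc2cc(C)nc3ccccc23)c1`: 55000 nM
Compound 2 `COc1cccc(NC(=O)COc2cc(C)nc3ccc(OC)cc23)c1`: 35000 nM
Compound 3 `COc1ccc2nc(C)cc(OCC(=O)Nc3cc(OC)c(Cl)cc3OC)c2c1`: 3000 nM

In a physicochemical assay for solubility, in phosphate buffer, measured as kinetic solubility, with a stated time of 1 h, at pH 7.4 (on this read-out lower numbers stand for lower solubility and higher numbers for higher solubility), compound 2 stands second highest of the three numbers. The value of compound 1 lies within the scatter of that of compound 2, so no order is drawn between the two. Compound 3 lies well below compound 2, beyond the scatter.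

Compound 4 `COc1ccc2nc(C)cc(OCC(=O)Nc3cccnc3)c2c1` has not been measured. Against compound 2 it carries pyridin-3-yl in place of 3-methoxyphenyl on an amide-type nitrogen. Within the data shown here, no measured pair shows this change, so its effect cannot be read from the data. In this assay a modest step toward higher solubility is expected, of a size near the scatter; the expected step is a 2.0-fold higher number from compound 2 to compound 4 (0.30 log units; within the scatter). For compound 4 the estimate in this assay is 70000 nM, with a range from 25000 nM to 200000 nM.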

Compound 4, solubility: 32000 nM
The estimate for compound 4 lay 2.2-fold (0.34 log units) above the measured number, within the range that was stated.
By their numbers in this assay, from the lowest: compound 3; then compounds 4, 2 and 1 (each within the scatter of the next).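

On the amide-type nitrogen, pyridin-3-yl in place of 3-methoxyphenyl gives a 1.1-fold lower number from compound 2 to compound 4 (0.04 log units; within the scatter) in this assay, the first single-place comparison available at this position. Exchanging a carbon-only aromatic ring for one with a hetero atom therefore leaves compound 2 and compound 4 indistinguishable on this read-out. No supporting measurement bears on why these two numbers sit so close.

Open, as far as these compounds go, is whether a carboxylic acid or a basic amine on a longer chain at this nitrogen would separate from compound 2. Also open, from the compounds shown here alone, is whether the same exchange behaves alike on the core of compound 1.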